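Purine ureas: Weinreb amide to ethyl ester swap

The source may report more compounds than this note shows. Statements on the series, on what has been measured and on what is new or still open speak of the compounds shown alone.

Measured compounds:
compound 1, `CCOC(=O)C[C@H]1[C@@H](O[Si](C)(C)C(C)(C)C)[C@H](n2cnc3c(NC(=O)Nc4ccccc4)ncnc32)O[C@@H]1COC(=O)NC`: 2.17 nM
compound 2, `CNC(=O)NC[C@H]1O[C@@H](n2cnc3c(NC(=O)Nc4ccccc4)ncnc32)[C@H](O[Si](C)(C)C(C)(C)C)[C@@H]1CC(=O)N(C)OC`: 85.3 nM

In a functional assay on SN12C cells (Homo sapiens) for antiproliferative activity (on this read-out higher numbers stand for weaker inhibition of growth and lower numbers for stronger inhibition of growth), compound 2 gives 85.3 nM, the higher of the two numbers; compound 1 gives 2.17 nM, well apart from it, though the two structures differ in more than one place. Compound 3, `CCOC(=O)C[C@H]1[C@@H](O[Si](C)(C)C(C)(C)C)[C@H](n2cnc3c(NC(=O)Nc4ccccc4)ncnc32)O[C@@H]1CNC(=O)NC`, is not yet measured; it differs from compound 2 by ethoxy in place of methoxy(methyl)amino on a carbonyl carbon, and shares that ethoxycarbonyl group with compound 1. A sizeable step downward is expected, a 5.7-fold lower number from compound 2 to compound 3 (0.75 log units; beyond the scatter), since compound 1 with the same ester group gives 2.17 nM. Compound 3 is estimated at 15 nM, within 3 nM to 80 nM.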

Compound 3, concentration for 50% growth inhibition: 9.1 nM
Compound 3: middle estimate off by 1.6-fold (0.22 log units), on the high side; low and high end bracket the measured number.
By their numbers in this assay, from the lowest: compound 1; then compound 3; then compound 2.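

In this assay the carbonyl substituent can now be read on its own: ethoxy in place of methoxy(methyl)amino gives a 9.4-fold lower number from compound 2 to compound 3 (0.97 log units; beyond the scatter) and so moves the read-out towards stronger growth inhibition. With ethoxycarbonyl held constant, the side chain on the saturated ring carbon also matters: (methylcarbamoyl)amino in place of (methylcarbamoyl)oxy gives a 4.2-fold higher number from compound 1 to compound 3 (0.62 log units; beyond the scatter). Nothing available explains either step.

On these data alone, whether the ethoxy step holds with the (methylcarbamoyl)oxy group remains open. So does the effect of a carboxylic acid, a primary amide or a longer propoxy group on that carbonyl carbon.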